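Compound 1 to compound 4: one group exchanged

A few compounds are considered here, and "the series" means these few. Any claim that something is new, unique, unknown or untested is made for them only; others in the source may bear on it.

Of the compounds shown here, three have numbers so far in an ADME assay on Vero cells (Chlorocebus sabaeus) for inhibition; a higher number here means that more compound is tolerated, a lower number that less compound is tolerated. Compound 1 `COc1ccc(/C=C2\CCC/C(=C\c3ccc(OC)cc3)C2=O)cc1` gives 178000 nM, the lowest of the three. Compound 3 `COc1ccc(/C=C2\CCC/C(=C\c3cccc(OC)c3OC)C2=O)cc1` gives 401000 nM, and compound 2 `COc1cccc(/C=C2\CCCCC2=O)c1OC` gives 720000 nM. Both of these stand higher than compound 1 by more than the scatter.

Compound 4 `COc1ccc(/C=C2\CCC/C(=C\c3ccccc3F)C2=O)cc1` has 2-fluorophenyl in place of 4-methoxyphenyl on a double-bonded chain carbon bound to a double-bonded ring carbon. Going by the values given here, no measured pair shows this exchange or any other single change, so the size of the step has no direct support. The direction rests only on the position of compound 1 at 178000 nM, the low end of the three values. In this assay a small rise is expected, possibly none beyond the scatter. The estimated step is a 1.5-fold higher number from compound 1 to compound 4 (0.16 log units; within the scatter). For compound 4 the estimated value is 260000 nM, with an expected range of 110000 nM to 600000 nM.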

Compound 4, half-maximal cytotoxic concentration: 270000 nM
Estimate against measurement, compound 4: 1.0-fold (0.02 log units) below; low and high end bracket the measured number.
By their numbers in this assay, from the lowest: compounds 1, 4, 3 and 2 (each within the scatter of the next, the first and the last beyond it).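

Going by these compounds alone, the exchange of 4-methoxyphenyl for 2-fluorophenyl on a double-bonded chain carbon bound to a double-bonded ring carbon gives the first single-place reading in this assay and amounts to a 1.5-fold higher number from compound 1 to compound 4 (0.18 log units; within the scatter) with the rest of the core of compound 1 held fixed. At this place, this assay does not separate the two substituted phenyl groups, although the entering group has no hydrogen-bond acceptor and the leaving group has one. Nothing measured here bears on the reason for this result.

From the compounds shown here alone, whether the same holds for a group of another kind at this place, such as an amine or a carboxylic acid, remains open. Also open, going by these compounds, is whether the 4-methoxyphenyl that remains in compound 4 would tolerate the same exchange.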